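Swapping the Aryl Group on the Sulfonamide Nitrogen

The source may report more compounds than this note shows. Statements on the series, on what has been measured and on what is new or still open speak of the compounds shown alone.

Among the measured compounds shown here, compound 1 `O=C1NCCN1c1ccc(S(=O)(=O)Nc2ccc(I)cc2)cc1` is the only member of this set with a numerical result: in a functional assay on M21 cells (Homo sapiens) for antiproliferative activity, read by sulforhodamine B assay, with a stated time of 48 h (on this read-out lower numbers stand for stronger inhibition and higher numbers for weaker inhibition), compound 1 gives 260 nM. Compound 2 `CCCCCCCc1ccc(NS(=O)(=O)c2ccc(N3CCNC3=O)cc2)cc1` carries heptyl in place of iodo on an aromatic carbon. In this assay compound 2 reaches only the limit of > 1000 nM. Compound 3 `CCCCCCOc1ccc(NS(=O)(=O)c2ccc(N3CCNC3=O)cc2)cc1` carries hexyloxy in place of iodo on an aromatic carbon. In this assay compound 3 likewise reaches only the limit of > 1000 nM. The two changes cost an at least 3.8-fold higher number from compound 1 to compound 2 (0.58 log units; beyond the scatter) and an at least 3.8-fold higher number from compound 1 to compound 3 (0.58 log units; beyond the scatter), and the limit of > 1000 nM in this assay, at which 2 of the 3 values shown sit, leaves the remaining step unreadable: a step that the two limits leave unreadable from compound 2 to compound 3.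

Compound 4 `COc1ccccc1NS(=O)(=O)c1ccc(N2CCNC2=O)cc1` is not yet measured. It differs from compound 1 as follows: 2-methoxyphenyl in place of 4-iodophenyl on a sulfonamide nitrogen. Neither measured step matches this change closely; both replaced iodo while keeping the rest of the group, whereas here the whole group is exchanged for a smaller one carrying a single hydrogen-bond acceptor. What the measured steps do show is that every departure from iodo so far weakened the compounds beyond the scatter. A weaker result is therefore expected for compound 4, with a 5.8-fold higher number from compound 1 to compound 4 (0.76 log units; beyond the scatter), quite possibly ending at the same limit. Compound 4 is estimated at 1500 nM, within 400 nM to 6000 nM.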

Compound 4, half-maximal inhibitory concentration: 300 nM
For compound 4 the middle estimate is 5.0-fold (0.70 log units) above the measured one; the measured number lies below the stated range.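

In this assay, the exchange of 4-iodophenyl for 2-methoxyphenyl on a sulfonamide nitrogen gives a 1.2-fold higher number from compound 1 to compound 4 (0.06 log units; within the scatter), so the two compounds cannot be told apart on this read-out. Among the compounds shown here, until now, every change at this position had cost activity; compound 4 is the first sign that the iodine is not needed here, since an aryl group without it matches the result of the iodinated parent. The loss seen with compound 2 and compound 3 therefore cannot be read as a general consequence of removing iodine: it holds for heptyl and hexyloxy, and compound 4 goes against it.

As far as these compounds go, the step exchanges the whole of 4-iodophenyl for 2-methoxyphenyl, so the contribution of each part of that change stays open, as does the outcome for an aryl group carrying an amine, a carboxylic acid or a shorter chain such as propyl. The step between compound 2 and compound 3 also remains unreadable, and the set cannot rank those two long-chain groups against each other: the limit of > 1000 nM in this assay, at which 2 of the 4 values shown sit.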